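A few compounds are considered here, and "the series" means these few. Any claim that something is new, unique, unknown or untested is made for them only; others in the source may bear on it.

Compound 1 `COc1cc2ncnc(Nc3ccc(NC(=O)c4ccc(C(C)(C)C)cc4)cc3)c2cc1OC` gives only a limit in a functional assay on MCF7 cells (Homo sapiens) for inhibition, read by MTT assay (a lower number here means a stronger inhibitor, a higher number a weaker inhibitor), namely > 100000 nM.
Compound 2 `COc1cc2ncnc(Nc3ccc(NC(=O)c4cccc(F)c4)cc3)c2cc1OC` gives 13600 nM in this assay.
Compound 3 `COc1cc2ncnc(Nc3ccc(NC(=O)c4ccccc4I)cc3)c2cc1OC` gives 37000 nM in this assay.

Among the three measured compounds, compound 1 is thus the only one for which this assay reports no number but a limit (the limit of > 100000 nM in this assay, at which 1 of the 3 values shown sits), while compound 2 and compound 3 each give a number. Compound 4 `COc1cc2ncnc(Nc3ccc(NC(=O)c4cccc(C(F)(F)F)c4)cc3)c2cc1OC` differs from compound 1 by 3-(trifluoromethyl)phenyl in place of 4-(tert-butyl)phenyl on a carbonyl carbon. For the measured compounds named here, two measured steps bear on this change, both leaving the same group on the same carbonyl carbon: an at least 7.3-fold lower number from compound 1 to compound 2 (0.86 log units; beyond the scatter) and an at least 2.7-fold lower number from compound 1 to compound 3 (0.43 log units; beyond the scatter). From these a lower number is expected for compound 4, with the step estimated as an at least 6.6-fold lower number from compound 1 to compound 4 (0.82 log units; beyond the scatter). Compound 4 is therefore expected to give about 15000 nM in this assay, within the range 5000 nM to 60000 nM.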

Compound 4, half-maximal inhibitory concentration: > 100000 nM
Compound 4 was reported as a limit (the forecaster's own chance of this, stated with the estimate: 10%); middle value at least 6.6-fold (0.82 log units) away from the limit.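

On the aromatic carbon that carries fluoro in compound 2, the group itself decides whether this assay returns a number: trifluoromethyl in place of fluoro weakens inhibition (an at least 7.3-fold higher number from compound 2 to compound 4 (0.86 log units; beyond the scatter)). Compound 4 also falls behind the 2-iodophenyl compound (an at least 2.7-fold higher number from compound 3 to compound 4 (0.43 log units; beyond the scatter)), while the step between compound 1 and compound 4 cannot be read, and a number is no longer reached for two compounds: the limit of > 100000 nM in this assay, at which 2 of the 4 values shown sit.

From the compounds shown here alone, how far compound 4 lies past its limit stays open. So does whether a methoxy group or an amine on that aromatic carbon would give a number.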